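The compounds below may be only part of what the source reports. "The series", "measured", "known", "first", "only" and "open" are said of these compounds alone.

Compound 2 `O=C1/C(=C/c2ccc(Cl)cc2)NS(=O)(=O)c2ccccc21` is the reference point of this small series. In an assay for inhibition of alkaline phosphatase, tissue-nonspecific isozyme (Homo sapiens), read by spectrophotometry, with stated times of 10 min and 20 min (a higher number here means a weaker inhibitor, a lower number a stronger inhibitor), compound 2 gives 250 nM, which is the only full number shown so far. Compound 1 `O=C1/C(=C/c2ccccc2Br)NS(=O)(=O)c2ccccc21` reaches only a limit of this assay, namely > 200000 nM. For the measured compounds named here, the one measured step, an at least 800-fold lower number from compound 1 to compound 2 (2.90 log units; beyond the scatter), is accordingly large, and it rests on (the limit of > 200000 nM in this assay, at which 1 of the 2 values shown sits). Compound 3 `O=C1/C(=C/c2ccc(Cl)cc2Cl)NS(=O)(=O)c2ccccc21` is not yet measured. Relative to compound 2 the change is chloro in place of hydrogen on an aromatic carbon, the chloro group of compound 2 being kept. The step that bears on it is an at least 800-fold lower number from compound 1 to compound 2 (2.90 log units; beyond the scatter): there a halogen left the position ortho to a large group while a chloro entered elsewhere on the ring, and the number fell far beyond the scatter. The present step puts a halogen back at the position ortho to a large group while keeping the chloro group, so a rise in the number is expected in this assay; the measured step combined two changes, so a smaller rise is expected here. Compound 3 is estimated at 2000 nM, with a range from 300 nM to 50000 nM, the expected step being an 8.0-fold higher number from compound 2 to compound 3 (0.90 log units; beyond the scatter).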

Compound 3, half-maximal inhibitory concentration: > 200000 nM
Compound 3 was reported as a limit; the forecaster's own chance of this, stated with the estimate: 15%; middle value at least 100-fold (2.00 log units) from the limit.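

In this assay, chloro in place of hydrogen on an aromatic carbon, ortho to a large group and meta to a chloro group, gives an at least 800-fold higher number from compound 2 to compound 3 (2.90 log units; beyond the scatter), and this single added heavy atom is enough even with the chloro group of compound 2 kept. The earlier step, an at least 800-fold lower number from compound 1 to compound 2 (2.90 log units; beyond the scatter), changed two places at once and could not say which of them carried the change in the number, whereas this step changes one place and ties a rise beyond the scatter to a halogen at this position. Compound 3 stands at a limit of the assay and not at a number, so the step gives a bound on the change and not its true size: the limit of > 200000 nM in this assay, at which 2 of the 3 values shown sit.

On these data alone, how far the number really rises remains open, as does whether a smaller or different group at this position, such as fluoro, methyl or methoxy, would keep a full number in this assay. Also open, as far as these compounds go, is how much the chloro group of compound 2 itself contributes, which a comparison with hydrogen, an amine or a carboxylic acid in its place would address.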